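This account rests on a few compounds, and the source may have more. Where it says the series, first, only, none or still open, it means among the compounds named here.

Measured compounds:
Compound 1 `Cc1c(C(=O)Nc2c(F)cc(-c3cccc(F)c3)cc2F)nc2ccc(OC(F)(F)F)cc2c1O`: 26.4%
Compound 2 `COc1ccc2nc(C(=O)Nc3ccc(-c4ccccc4)cc3)c(C)c(O)c2c1`: 23.5%
Compound 3 `Cc1c(C(=O)Nc2ccc(-c3ccccc3)cc2)nc2ccccc2c1O`: 21.5%

In a functional assay on Hep 3B2 cells (Homo sapiens) for antiproliferative activity, read by MTT assay, with a stated time of 24 h, tested at 3.7 ug/mL (a lower number here means a weaker effect, a higher number a stronger effect of the compound at the concentration tested), compound 2 gives 23.5%, the second highest of the three numbers; the three values sit within the scatter of one another, so no order among them can be read. Within the data shown here, the only measured step, a number 2 percentage points lower from compound 2 to compound 3 (within the scatter), came from hydrogen in place of methoxy on an aromatic carbon and stayed within the scatter. Compound 4 `COc1ccc2nc(C(=O)Nc3ccc(-c4ccccc4)cc3)c(C)c(C(=O)O)c2c1` differs from compound 2 by carboxy in place of hydroxy on an aromatic carbon. Among the measured compounds shown here, no measured step touches this position or this group, so the direction is open; the expected step is a number 0.5 percentage points lower from compound 2 to compound 4 (within the scatter), set at no change beyond the scatter, with a wide range to cover the uncertainty. Compound 4 is estimated at 23%, between 8% and 38%.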

Compound 4, a percentage reported as inhibition, at one concentration (the size of the read-out at that concentration, not a potency): 19.4%
Compound 4: middle estimate off by 3.6 percentage points, on the high side, and the stated range covers the measured number.
By their numbers in this assay, from the lowest: compounds 4, 3, 2 and 1 (each within the scatter of the next).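

The earlier compounds shown here left this position untouched. Opposite the ring nitrogen, carboxy in place of hydroxy gives a number 4.1 percentage points lower from compound 2 to compound 4 (within the scatter) in this assay, so at this single concentration hydroxy can be exchanged for carboxy with no change that can be read. No available evidence bears on this result. Still open, as far as these compounds go, is how an amine or an ester at this position would read, and whether the same exchange would stay within the scatter on the core of compound 1 or compound 3.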